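This account rests on a few compounds, and the source may have more. Where it says the series, first, only, none or still open, it means among the compounds named here.

Measured compounds, with their numbers in an assay on microsomes from liver for inhibition of sterol O-acyltransferase 1 (Rattus norvegicus); a higher number here means a weaker inhibitor, a lower number a stronger inhibitor:
compound 1, `CCCCCCN(CCCCCSc1nc2ccccc2o1)C(=O)Nc1ccc(F)cc1F`, gives 51000 nM.
compound 2, `CCCCCCN(CCCCCSc1nc2ccc[nH]c-2n1)C(=O)Nc1ccc(F)cc1F`, gives 3600 nM.
compound 3, `CCCCCCCN(CCCCCSc1nc(O)c2ccccc2n1)C(=O)Nc1ccc(F)cc1F`, gives 4000 nM.

Compound 3 stands second highest of the three numbers in this assay; its gap to compound 2 lies within the scatter, while it sits far below compound 1. For the measured compounds named here, the only single-point step on record is a 14-fold lower number from compound 1 to compound 2 (1.15 log units; beyond the scatter), a large shift on exchanging one aromatic group for another on the sulfur. Compound 4, `CCCCCCCN(CCCCCSc1n[nH]c(-c2ccccc2)n1)C(=O)Nc1ccc(F)cc1F`, differs from compound 3 by 5-phenyl-1H-1,2,4-triazol-3-yl in place of 4-hydroxyquinazolin-2-yl on a sulfur, again an exchange of the aromatic group on the sulfur. It is not the same exchange, so the earlier step sets only the scale such a swap can reach, not its direction. Compounds 2 and 3 carry different groups there yet sit within the scatter of each other, which points toward a modest step here. Compound 4 is therefore expected close to compound 3, with a 1.3-fold lower number from compound 3 to compound 4 (0.12 log units; within the scatter). The estimate for compound 4 in this assay is 3000 nM, range 800 nM to 12000 nM.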

Compound 4, half-maximal inhibitory concentration: 4000 nM
Compound 4: middle estimate off by 1.3-fold (0.12 log units), on the low side; measured number inside the range.
By their numbers in this assay, from the lowest: compounds 2, 3 and 4 (each within the scatter of the next); then compound 1.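

In this assay, 5-phenyl-1H-1,2,4-triazol-3-yl in place of 4-hydroxyquinazolin-2-yl on the sulfur gives no change at the digits printed from compound 3 to compound 4 (within the scatter). This position therefore tolerates an exchange of a six-membered aromatic ring with hetero atoms for a five-membered aromatic ring with hetero atoms, at an equal count of 11 heavy atoms, so a swap of aromatic group here need not bring a shift of the size of a 14-fold lower number from compound 1 to compound 2 (1.15 log units; beyond the scatter). Nothing on hand explains why these two groups match in this assay.

Open, on these data alone, is whether an amine or a carboxylic acid on the phenyl of the triazole group would keep the number in this assay unchanged. Also open, as far as these compounds go, is how a plain methyl in place of the whole aromatic group on the sulfur would read.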